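Swapping fluoro for bromo on an inactive urea scaffold

The source may report more compounds than this note shows. Statements on the series, on what has been measured and on what is new or still open speak of the compounds shown alone.

Compound 2 `CC1(C)CC(NC(=O)Nc2cccc(Cl)c2)c2cc(F)ccc2O1` is known in a functional assay (aorta) with Rattus norvegicus as the target (a higher number here means that more compound is needed for the effect, a lower number that less compound is needed), only as a limit of the assay: compound 2 gives > 300000 nM, which sits at the limit of > 300000 nM in this assay, at which 1 of the 2 values shown sits. Its companion compound 1 `Cc1ccccc1NC(=O)NC1CC(C)(C)Oc2ccc(Br)cc21`, a urea of the same kind with bromo on the fused ring system, is likewise known only as a limit, giving > 30000 nM in this assay. Compound 3 `CC1(C)CC(NC(=O)Nc2cccc(Cl)c2)c2cc(Br)ccc2O1` differs from compound 2 by bromo in place of fluoro on an aromatic carbon. For the measured compounds named here, no measured step exists between compound 2 and compound 3, and the two limits at hand do not reveal a direction; an expected step from compound 2 to compound 3 of an at least 3.0-fold lower number from compound 2 to compound 3 (0.47 log units; beyond the scatter) is therefore no more than a guess that nothing beyond the scatter will appear, because compound 1 with its bromo already sits at the limit of > 30000 nM in this assay, at which 1 of the 2 values shown sits. Compound 3 is accordingly expected to give about 100000 nM in this assay, within a range from 30000 nM to 300000 nM, most likely again reported only as a limit.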

Compound 3, half-maximal effective concentration: > 30000 nM
Compound 3 was reported as a limit (the forecaster's own chance of this, stated with the estimate: 80%); the middle value does not contradict the limit.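

In this assay, for the compounds shown here, compound 3, like compound 1 and compound 2, is known only as a limit, so no step from compound 2 or compound 1 to compound 3 can be read. The compounds shown leave open whether bromo in place of fluoro, or 3-chlorophenyl in place of 2-methylphenyl, changes the number at all.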